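Compound 4: ((chloromethyl)carbonyl)amino in place of propoxy

This account rests on a few compounds, and the source may have more. Where it says the series, first, only, none or still open, it means among the compounds named here.

Measured compounds:
compound 1, `CCCOC(=O)N1CCCc2cc(S(=O)(=O)N3CC(c4ccccc4)NC3=O)ccc21`, gives > 20000 nM in a functional assay on K562 cells (Homo sapiens) for antiproliferative activity, read by MTT assay (on this read-out higher numbers stand for weaker inhibition and lower numbers for stronger inhibition), a limit of the assay.
compound 2, `O=C(OCCCl)N1CCCc2cc(S(=O)(=O)N3CC(c4ccccc4)NC3=O)ccc21`, gives 10600 nM in this assay.
compound 3, `O=C1NC(c2ccccc2)CN1S(=O)(=O)c1ccc2c(c1)CCCN2C(=O)C(F)(F)F`, gives > 20000 nM in this assay, a limit of the assay.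

Compound 1 is thus known in this assay only as a limit, not a number. Two of the three values sit at the limit of > 20000 nM in this assay, at which 2 of the 3 values shown sit, and only compound 2 gives a number. Compound 4, `O=C(CCl)NC(=O)N1CCCc2cc(S(=O)(=O)N3CC(c4ccccc4)NC3=O)ccc21`, differs from compound 1 by ((chloromethyl)carbonyl)amino in place of propoxy on a carbonyl carbon. For the measured compounds named here, no measured step makes this exact change. The closest is an at least 1.8-fold lower number from compound 1 to compound 2 (0.27 log units; that floor lies within the scatter), where a chloro entering the chain moved the value off the limit, though the floor of that step lies within the scatter. The steps a step that the two limits leave unreadable from compound 1 to compound 3 and an at least 1.8-fold higher number from compound 2 to compound 3 (0.27 log units; that floor lies within the scatter) add little. Compound 4 also brings in a chloro, and its expected step is an at least 1.6-fold lower number from compound 1 to compound 4 (0.22 log units; that floor lies within the scatter). Compound 4 is estimated at 12000 nM, with a range from 5000 nM to 30000 nM.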

Compound 4, half-maximal inhibitory concentration: 515 nM
Estimate against measurement, compound 4: 23-fold (1.37 log units) above, outside the stated range (below it).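

For the compounds shown here, with ((chloromethyl)carbonyl)amino on this carbonyl carbon, this assay shows an at least 38-fold lower number from compound 1 to compound 4 (1.58 log units; beyond the scatter) and an at least 38-fold lower number from compound 3 to compound 4 (1.58 log units; beyond the scatter) as the first large steps at this position. Compound 2 also carries a chloro, yet a 21-fold lower number from compound 2 to compound 4 (1.31 log units; beyond the scatter) follows, so a chloro alone does not account for the change among these compounds. The first two steps are floors only, because compound 1 and compound 3 each stand at a limit: the limit of > 20000 nM in this assay, at which 2 of the 4 values shown sit.

The compounds shown leave open whether the step needs the chloro or the added amino nitrogen. An acetylamino group on the same carbonyl carbon would separate the two.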